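The compounds below may be only part of what the source reports. "The series", "measured", "known", "first", "only" and "open" are said of these compounds alone.

The measured compounds:
compound 1, `CCOC(=O)C1=C(C)NC(C)=C(C(=O)OCC)C1c1c(-c2ccc(F)cc2)nc2sccn12`, gives 64 nM;
compound 2, `CCOC(=O)C1=C(C)NC(C)=C(C(=O)OCC)C1c1c(-c2ccc(F)c(F)c2)nc2sccn12`, gives 21 nM;
compound 3, `CCOC(=O)C1=C(C)NC(C)=C(C(=O)OCC)C1c1c(-c2cc(F)c(F)cc2F)nc2sccn12`, gives 160 nM.

All three share one core and differ only in the fluorinated phenyl attached to it. In an ADME assay on Left cardiac atrium (Cavia porcellus) (on this read-out lower numbers stand for an effect already at smaller amounts and higher numbers for an effect only at larger amounts of compound), compound 3 stands at the highest number of the three: a 2.5-fold higher number from compound 1 to compound 3 (0.40 log units; beyond the scatter), and a 7.6-fold higher number from compound 2 to compound 3 (0.88 log units; beyond the scatter). In the other direction, a 3.0-fold lower number from compound 1 to compound 2 (0.48 log units; beyond the scatter). So changes to the pattern on this phenyl have moved the number by modest amounts both ways.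

Compound 4, `CCOC(=O)C1=C(C)NC(C)=C(C(=O)OCC)C1c1c(-c2ccc(Br)c([N+](=O)[O-])c2)nc2sccn12`, carries a different phenyl: 4-bromo-3-nitrophenyl in place of 2,4,5-trifluorophenyl on an aromatic carbon. For the measured compounds named here, no measured step involves bromine or a nitro group, so the three steps bear on this change only indirectly, by showing the range over which varying this phenyl shifted the read-out. Going by the values given here, with no direct precedent, the number for compound 4 is expected to fall somewhere within the span covered by the measured three rather than outside it, which amounts to an estimated 2.3-fold lower number from compound 3 to compound 4 (0.36 log units; beyond the scatter). Compound 4 is therefore estimated at 70 nM, with a wide range from 15 nM to 350 nM reflecting the absence of a matching step.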

Compound 4, half-maximal effective concentration: 1270 nM
Beside the measured number, compound 4's estimate is 18-fold (1.26 log units) below it; the measured number lies above the stated range.
By their numbers in this assay, from the lowest: compound 2; then compound 1; then compound 3; then compound 4.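

In this assay, replacing the fluorinated phenyl with 4-bromo-3-nitrophenyl gives a 7.9-fold higher number from compound 3 to compound 4 (0.90 log units; beyond the scatter), and the same comparison with the other two compounds gives a 20-fold higher number from compound 1 to compound 4 (1.30 log units; beyond the scatter) and a 60-fold higher number from compound 2 to compound 4 (1.78 log units; beyond the scatter). The steps among the three fluorinated compounds were all modest, whereas these last two are large, so the group at this place on the shared core can push the number well beyond the span seen with fluorine patterns alone, and compound 4 now has the highest number of the four. The compounds shown offer no measured explanation for this rise.

Bromine and the nitro group enter together in a single change, so their separate contributions cannot be told apart, and a phenyl carrying only one of the two would be needed to separate them. From the compounds shown here alone, it also remains open how this read-out would respond to quite different groups on this phenyl, such as an amine, a carboxylic acid or a longer chain, and whether any of them would bring the number down again.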